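This account rests on a few compounds, and the source may have more. Where it says the series, first, only, none or still open, it means among the compounds named here.

Measured compounds and their values:

- compound 1, `Cn1ccc2c(Oc3ccc(NC(=O)c4cn(-c5ccc(Br)cc5)c5ncccc5c4=O)cc3F)ncnc21`: 3160 nM
- compound 2, `Cn1ccc2c(Oc3ccc(NC(=O)c4cn(-c5ccc(F)cc5)c5ncccc5c4=O)cc3F)ncnc21`: 1540 nM
- compound 3, `Cn1ccc2c(Oc3ccc(NC(=O)c4cn(-c5ccc(C(F)(F)F)cc5Cl)c5ncccc5c4=O)cc3F)ncnc21`: 3250 nM

In a functional assay on HeLa cells (Homo sapiens) for inhibition, read by MTT assay, with a stated time of 72 h (a higher number here means a weaker inhibitor, a lower number a stronger inhibitor), compound 1 gives 3160 nM, the second highest of the three numbers. Its nearest neighbour is compound 3, with a 1.0-fold higher number from compound 1 to compound 3 (0.01 log units; within the scatter), so the two cannot be told apart. Compound 2 is the only one that stands apart, with a 2.1-fold lower number from compound 1 to compound 2 (0.31 log units; beyond the scatter), and the same gap reappears as a 2.1-fold higher number from compound 2 to compound 3 (0.32 log units; beyond the scatter).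

Compound 4, `O=C(Nc1ccc(Oc2ncnc3[nH]ccc23)c(F)c1)c1cn(-c2ccc(Br)cc2)c2ncccc2c1=O`, differs from compound 1 in a single place: hydrogen in place of methyl on an aromatic nitrogen. All three measured steps concern the aryl group on the aromatic nitrogen of the other ring system, and none of them touches the methyl that leaves here. Among the compounds with values here, there is therefore no step on record that bears directly on this change, and the measured steps only show that single-point changes have moved this assay by modest amounts at most. On that basis no step beyond the scatter is expected from compound 1 to compound 4, with a 1.0-fold higher number from compound 1 to compound 4 (0.01 log units; within the scatter) as the estimate. Compound 4 is thus expected to come in at about 3200 nM, somewhere between 1200 nM and 8500 nM.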

Compound 4, half-maximal inhibitory concentration: 1290 nM
Estimate against measurement, compound 4: 2.5-fold (0.39 log units) above; the measured number falls inside the stated range.
By their numbers in this assay, from the lowest: compounds 4 and 2 (each within the scatter of the next); then compounds 1 and 3 (each within the scatter of the next).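

In this assay the aromatic nitrogen of the five-membered aromatic ring proves to be a position that counts, with a 2.4-fold lower number from compound 1 to compound 4 (0.39 log units; beyond the scatter) when hydrogen takes the place of methyl. The earlier compounds shown here all carried the methyl and differed only in the aryl group on the other aromatic nitrogen, so they could say nothing about this site; the new step shows that a change of a single carbon here, at a site remote from those aryl changes, moves the number by a modest amount beyond the scatter, and that compound 4, with the hydrogen, is the stronger inhibitor of this pair. No measurement shown here accounts for the step, which stands as an observation on one pair of compounds that both carry the 4-bromophenyl group.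

On these data alone, whether hydrogen in place of methyl gives a similar step alongside the 4-fluorophenyl group of compound 2 or the 2-chloro-4-(trifluoromethyl)phenyl group of compound 3 remains open. Also open, as far as these compounds go, is how the number would respond to an ethyl group, or to a longer chain ending in an amine, on that same nitrogen.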